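This account rests on a few compounds, and the source may have more. Where it says the series, first, only, none or still open, it means among the compounds named here.

Values from a functional assay on SGC-7901 cells (Homo sapiens) for antiproliferative activity, read by sulforhodamine B assay, with a stated time of 72 h (on this read-out lower numbers stand for stronger inhibition and higher numbers for weaker inhibition), come first here.

- compound 1 (`S=C(NCc1ccccc1)N/N=C/c1ccc2ccccc2n1`) gives 53700 nM
- compound 2 (`S=C(N/N=C/c1ccc2ccccc2n1)Nc1ccccc1Br`) gives > 100000 nM as a limit of the assay, not a number
- compound 3 (`Fc1cccc(NC(=S)N/N=C/c2ccc3ccccc3n2)c1`) gives 79900 nM

Compound 3 has a measured number close to that of compound 1, and the gap between them (a 1.5-fold higher number from compound 1 to compound 3 (0.17 log units; within the scatter)) lies within the usual scatter. Compound 2 offers only its limit (the limit of > 100000 nM in this assay, at which 1 of the 3 values shown sits) for comparison.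

Compound 4 (`S=C(N/N=C/c1ccc2ccccc2n1)Nc1ccccc1`) carries hydrogen in place of fluoro on an aromatic carbon, turning 3-fluorophenyl into phenyl. Going by the values given here, no measured step makes this exact swap. The closest evidence comes from whole-group changes on the amide-type nitrogen (an at least 1.8-fold higher number from compound 1 to compound 2 (0.27 log units; that floor lies within the scatter); an at least 1.2-fold lower number from compound 2 to compound 3 (0.09 log units; that floor lies within the scatter)), and the floors of both also lie within the scatter. A step beyond the scatter is therefore not expected in this assay for this smaller change.

The estimated step (a 1.1-fold lower number from compound 3 to compound 4 (0.06 log units; within the scatter)) is expected to stay within the scatter. The expected value for compound 4 is 70000 nM with an estimated range from 35000 nM to 100000 nM in this estimate.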

Compound 4, half-maximal inhibitory concentration: 26500 nM
Estimate against measurement, compound 4: 2.6-fold (0.42 log units) above, outside the stated range (below it).
By their numbers in this assay, from the lowest: compound 4; then compounds 1 and 3 (each within the scatter of the next). At a limit, above all of these: compound 2.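

In this assay, a change of a single atom on the ring turns out to matter: a 3.0-fold lower number from compound 3 to compound 4 (0.48 log units; beyond the scatter), a larger step than the earlier whole-group swaps could establish. The bare phenyl group also separates from benzyl on the amide-type nitrogen, with a 2.0-fold lower number from compound 1 to compound 4 (0.31 log units; beyond the scatter), although 3-fluorophenyl and benzyl had stayed within the scatter of each other. Hydrogen in place of bromo gives an at least 3.7-fold lower number from compound 2 to compound 4 (0.57 log units; beyond the scatter), a floor and not an exact size, as compound 2 stands at a limit and not at a number: the limit of > 100000 nM in this assay, at which 1 of the 4 values shown sits.

The compounds shown leave open whether a group other than a halogen on this ring, such as an amine or a methoxy group, would lower the number further or raise it. They also leave open whether fluoro at another place on the ring would cost as much.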